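Fluoro on the benzoyl phenyl: solubility outlook

The source may report more compounds than this note shows. Statements on the series, on what has been measured and on what is new or still open speak of the compounds shown alone.

Compound 1 `COC(=O)Nc1nc2cc(Sc3ccccc3)ccc2n1COP(=O)(O)O` in a physicochemical assay for solubility, at pH 7.4 (on this read-out lower numbers stand for lower solubility and higher numbers for higher solubility), gives 130000000 nM. Compound 2 `COC(=O)Nc1nc2cc(C(=O)c3ccccc3)ccc2n1COP(=O)(O)O` reaches only a limit of this assay, > 50000000 nM, and so sits at the limit of > 50000000 nM in this assay, at which 1 of the 2 values shown sits. The step that the limit leaves unreadable from compound 1 to compound 2 therefore has no readable size. Compound 3 `COC(=O)Nc1nc2cc(C(=O)c3ccc(F)cc3)ccc2n1COP(=O)(O)O` differs from compound 2 by fluoro in place of hydrogen on an aromatic carbon, on an aromatic carbon of a six-membered aromatic ring of carbon only, para to a large group. Within the data shown here, no measured step bears on this change, so no shift beyond the scatter is expected. The expected step is a step that the limit leaves unreadable from compound 2 to compound 3. Compound 3 is estimated at 60000000 nM, between 20000000 nM and 150000000 nM.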

Compound 3, solubility: > 50000000 nM
Compound 3: a limit, no number; the forecaster's own chance of this, stated with the estimate: 50%; the middle value is on the limit's open side.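

Among these compounds, compound 3, like compound 2, gives only a limit in this assay, and no step among compound 1, compound 2 and compound 3 can be read. The compounds shown leave open what size, if any, the fluoro step has on this read-out.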